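Replacing the lactone ring of compound 2 with an acetal

The source may report more compounds than this note shows. Statements on the series, on what has been measured and on what is new or still open speak of the compounds shown alone.

Of the compounds shown here, two have been measured in an assay on microsomes from liver for inhibition of sterol O-acyltransferase 1 (Rattus norvegicus); a lower number here means a stronger inhibitor, a higher number a weaker inhibitor. Compound 1 `C[C@@]1(O)CC(=O)OC(CSc2nc(-c3ccc(Cl)cc3)c(-c3ccc(Cl)cc3)[nH]2)C1` gives 180 nM. Among the compounds with values here, compound 2 `CC1=CC(=O)OC(CSc2nc(-c3ccccc3)c(-c3ccccc3)[nH]2)C1` gives 200 nM, a number that lies within the usual scatter of the one for compound 1, so the two cannot be told apart. Compound 3 `COC(CSc1nc(-c2ccccc2)c(-c2ccccc2)[nH]1)OC` has not been measured; it differs from compound 2 by a group of 5 heavy atoms (3 carbon, 2 oxygen; no ring) in place of a group of 8 heavy atoms (6 carbon, 2 oxygen; one six-membered non-aromatic ring with 1 hetero atom), on a saturated chain carbon bound to a sulfur. Within the data shown here, the measured pair offers no step of this kind, so the expectation rests on the size of the change alone. Compound 3 is expected to give a weaker result, a step of a 3.5-fold higher number from compound 2 to compound 3 (0.54 log units; beyond the scatter) beyond the scatter. The estimate for compound 3 is 700 nM, with a range from 200 nM to 2500 nM.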

Compound 3, half-maximal inhibitory concentration: 580 nM
The estimate for compound 3 lay 1.2-fold (0.08 log units) above the measured number, and the stated range covers the measured number.
By their numbers in this assay, from the lowest: compounds 1 and 2 (each within the scatter of the next); then compound 3.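

In this assay, putting dimethoxymethyl in place of the six-membered ring group on the saturated chain carbon bound to a sulfur gives a 2.9-fold higher number from compound 2 to compound 3 (0.46 log units; beyond the scatter). This shows that the group at this position affects the result, and that the ring is not required for inhibition in the nanomolar range. No measurement shown explains the step. Ring, size and double bonds all change together here, so their separate shares remain unknown. On these data alone, how a carboxylic acid, an amine or a longer chain would fare at this position also remains open.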